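The compounds below may be only part of what the source reports. "The series", "measured", "known", "first", "only" and "open" are said of these compounds alone.

Two compounds have numbers in an assay on CHO cells for displacement of a labelled ligand from prostaglandin E2 receptor EP3 subtype (Homo sapiens), read by radioligand binding; a lower number here means a stronger inhibitor, a higher number a weaker inhibitor. Compound 1, `CC(C)C(Cc1ncc[nH]1)c1ccc(-c2ccc3cccc(F)c3c2)[nH]c1=O`, gives 11 nM. Compound 2, `CCn1ncc2c(F)cc(-c3ccc(C(CC)(CC)c4nncn4C)c(=O)[nH]3)cc21`, gives 54 nM. Compound 1 thus holds the lower of the two numbers, and its gap to compound 2 lies beyond the scatter. Compound 3, `CC(C)C(c1cnc(N)s1)c1ccc(-c2ccc3cccc(F)c3c2)[nH]c1=O`, is not yet measured. It differs from compound 1 in one place: 2-amino-1,3-thiazol-5-yl in place of (1H-imidazol-2-yl)methyl on a saturated chain carbon bound to an aromatic carbon and a saturated chain carbon. Among the measured compounds shown here, no measured pair shows this change, so its size is unknown from the data. For compound 3 a modest rise is expected, a 2.3-fold higher number from compound 1 to compound 3 (0.36 log units; beyond the scatter), near the edge of the scatter. The estimate for compound 3 is 25 nM, with a range from 6 nM to 100 nM.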

Compound 3, inhibition constant: 16 nM
For compound 3 the middle estimate is 1.6-fold (0.19 log units) above the measured one; measured number inside the range.
By their numbers in this assay, from the lowest: compounds 1 and 3 (each within the scatter of the next); then compound 2.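

On the saturated chain carbon bound to an aromatic carbon and a saturated chain carbon, 2-amino-1,3-thiazol-5-yl in place of (1H-imidazol-2-yl)methyl gives a 1.5-fold higher number from compound 1 to compound 3 (0.16 log units; within the scatter) in this assay. For this pair, the position accepts a sulfur-containing five-membered aromatic ring without the methyl link, and the number stays within the scatter. Nothing measured here explains why the two groups read alike. Still open, from the compounds shown here alone, is whether the amine on the thiazole matters, and whether a carboxylic acid at this position would hold the number.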